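Shrinking the Ring on the Amide Nitrogen

The compounds below may be only part of what the source reports. "The series", "measured", "known", "first", "only" and "open" are said of these compounds alone.

Among the measured compounds shown here, compound 2 `CCC(C)C(NC(=O)n1nnc2ccccc21)C(=O)NC1CCCCC1` is the only one of the three compounds with a number in a functional assay on CCRF-CEM cells (Homo sapiens) for inhibition; on this read-out higher numbers stand for weaker inhibition and lower numbers for stronger inhibition: it gives 107000 nM. Compound 1 `CC(C)C(NC(=O)NO)C(=O)NC1CCCC1` stops at > 200000 nM in this assay, which is a limit rather than a number. Compound 3 `CC(C)C1NC(=O)N(C2CCCCC2)C1=O` likewise stops at the limit of > 200000 nM. Two of the three results thus sit at the limit of > 200000 nM in this assay, at which 2 of the 3 values shown sit. Compound 4 `CCC(C)C(NC(=O)n1nnc2ccccc21)C(=O)NC1CCCC1` is built from compound 2 by one change: cyclopentyl in place of cyclohexyl on an amide-type nitrogen. For the measured compounds named here, no measured pair shows this change, so the expectation is a step no larger than the usual scatter, in no fixed direction. The expected result for compound 4 is 130000 nM, within 50000 nM to 300000 nM. This amounts to an expected step of a 1.2-fold higher number from compound 2 to compound 4 (0.08 log units; within the scatter) that stays within the scatter.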

Compound 4, half-maximal inhibitory concentration: 116000 nM
Compound 4: middle estimate off by 1.1-fold (0.05 log units), on the high side; the range from low to high includes it.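

This first measured pair for the change, in this assay, gives a 1.1-fold higher number from compound 2 to compound 4 (0.04 log units; within the scatter). On this read-out the five-membered and six-membered carbon rings on the amide-type nitrogen cannot be told apart, so cyclopentyl serves here as well as cyclohexyl. Nothing measured here explains why the two ring sizes read alike.

Still open, on these data alone, is whether a much smaller group such as methyl, or an open chain such as n-hexyl, would read the same on this nitrogen. As far as these compounds go, a ring carrying an amine or a carboxylic acid is equally open.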